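This account rests on a few compounds, and the source may have more. Where it says the series, first, only, none or still open, it means among the compounds named here.

Compound 1 `Cc1cccc2c(-c3ccc4cccc(F)c4n3)c[nH]c12`: 0.983 h
Compound 2 `Fc1cc(F)c2[nH]cc(-c3ccc4ccccc4n3)c2c1`: 0.45 h
Compound 3 `Cc1ccc2c(-c3ccc4ccccc4n3)c[nH]c2c1F`: 0.25 h

These three compounds were measured in an ADME assay on microsomes from liver (Homo sapiens) for metabolic stability, using NADPH, with a stated time of 40 min, tested at 2 uM; on this read-out higher numbers stand for a longer-lived compound and lower numbers for a shorter-lived compound. Compound 1 has the highest number of the three, and the lower numbers of compound 2 and compound 3 both lie beyond the usual scatter from it.

Compound 4 `Cc1cccc2ccc(-c3c[nH]c4c(C)cccc34)nc12` departs from compound 1 by one exchange, methyl in place of fluoro on an aromatic carbon of a six-membered aromatic ring of carbon only, part of a fused or bridged system of two rings. Among the compounds with values here, no measured pair shows this exchange alone, so the data give no direct guide to its size in this assay. A modest fall is expected, since compound 1 at 0.983 h sits at the top of a small set that reaches down to compound 3 at 0.25 h. The expected change is a 1.8-fold lower number from compound 1 to compound 4 (0.25 log units; within the scatter), which may not clear the scatter. For compound 4 the estimated half-life is 0.55 h, with an expected range of 0.22 h to 1.2 h.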

Compound 4, half-life: 1.62 h
The estimate for compound 4 lay 2.9-fold (0.47 log units) below the measured number; measured number outside the range, above it.
By their numbers in this assay, from the lowest: compounds 3 and 2 (each within the scatter of the next); then compounds 1 and 4 (each within the scatter of the next).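

In this assay, within the data shown here, the exchange of fluoro for methyl gives a 1.6-fold higher number from compound 1 to compound 4 (0.22 log units; within the scatter) and is the first comparison here of compounds that differ in one place. On an aromatic carbon of a six-membered aromatic ring of carbon only, part of a fused or bridged system of two rings, the half-life therefore does not separate methyl from fluoro, and the two groups are interchangeable at this place on this read-out alone. No measurement offered here accounts for this result.

The compounds shown leave open whether a larger or different group at this place, such as a methoxy group, an amine or a carboxylic acid, would move the half-life beyond the scatter. They also leave open whether the same exchange would behave alike on another core.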